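Swapping Cyano for Fluoro: What Two Numbers Suggest

This account rests on a few compounds, and the source may have more. Where it says the series, first, only, none or still open, it means among the compounds named here.

Of the compounds shown here, two measured so far share one core. Compound 1 `Cc1ccc2c(c1)CCN2S(=O)(=O)c1ccc(-c2cnc(C3CC3)o2)cc1` carries a methyl on an aromatic carbon, and in a functional assay on A549 cells (Homo sapiens) for inhibition, read by MTT assay, tested at 10 uM (on this read-out higher numbers stand for more inhibition at the one concentration tested (going by the name of the read-out) and lower numbers for less inhibition), compound 1 gives 63.4%. Compound 2 `N#Cc1ccc2c(c1)CCN2S(=O)(=O)c1ccc(-c2cnc(C3CC3)o2)cc1` carries a cyano at that place instead; in this assay compound 2 gives 28.4%. Among the measured compounds shown here, compound 2 thus stands lowest of the two numbers, the single step being a number 35 percentage points lower from compound 1 to compound 2 (beyond the scatter). The unmeasured compound 3 `O=S(=O)(c1ccc(-c2cnc(C3CC3)o2)cc1)N1CCc2cc(F)ccc21` differs from compound 2 as fluoro in place of cyano on an aromatic carbon. For the measured compounds named here, the only step that bears on this change is the one between compound 1 and compound 2, where cyano arrived and the number fell sharply; now the cyano leaves again, so a rise is expected, though no measured compound carries fluoro at this place and the size is uncertain. Compound 3 is therefore estimated at 50%, within 30% to 70%, an expected step of a number 21.6 percentage points higher from compound 2 to compound 3 (beyond the scatter).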

Compound 3, a percentage reported as inhibition, at one concentration (the size of the read-out at that concentration, not a potency): 36.1%
Compound 3: middle estimate off by 13.9 percentage points, on the high side; the range from low to high includes it.
By their numbers in this assay, from the lowest: compounds 2 and 3 (each within the scatter of the next); then compound 1.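

In this assay, fluoro in place of cyano gives a number 7.7 percentage points higher from compound 2 to compound 3 (within the scatter), so at this aromatic carbon the two groups cannot be told apart and losing the cyano does not by itself restore the number. Fluoro in place of methyl gives a number 27.3 percentage points lower from compound 1 to compound 3 (beyond the scatter), which shows that the drop is not tied to cyano alone, since it also appears with a second, different group, leaving methyl as the one group of the three that stands apart. Nothing measured here explains why methyl differs from the other two groups.

Three groups at one place cannot show whether the higher number belongs to methyl alone or would also come with an ethyl, a methoxy or an amine. From the compounds shown here alone, whether the same picture would hold with a different group in place of the cyclopropyl also remains open.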